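The compounds below may be only part of what the source reports. "The series", "measured", "known", "first", "only" and "open" are said of these compounds alone.

Working notes on the shared core of compound 1 `CCc1ccc2c(c1)[n+]([O-])c(NCCN(C)C)n[n+]2[O-]`, compound 2 `CCOc1ccc2c(c1)[n+]([O-])c(NCCN(C)C)n[n+]2[O-]` and compound 3 `CN(C)CCNc1n[n+]([O-])c2ccc(OCC3CC3)cc2[n+]1[O-]`. In a physicochemical assay for solubility, in the presence of a further agent that is not named here (a lower number here means a less soluble compound, a higher number a more soluble compound), compound 1 gives > 49000000 nM, a limit of the assay. In this assay compound 2 gives > 50000000 nM, also a limit. In this assay compound 3 gives > 55000000 nM, again a limit; compound 3 therefore stands at the upper edge of what this assay reports, with no numbered value of its own. The steps a step that the two limits leave unreadable from compound 1 to compound 3 and a step that the two limits leave unreadable from compound 2 to compound 3 cannot be sized, as the limit of > 49000000 nM in this assay, at which 1 of the 3 values shown sits, the limit of > 50000000 nM in this assay, at which 1 of the 3 values shown sits, and the limit of > 55000000 nM in this assay, at which 1 of the 3 values shown sits, all describe limits rather than numbers.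

Compound 4 `COCCOc1ccc2c(c1)[n+]([O-])c(NCCN(C)C)n[n+]2[O-]` arises from compound 3 by methoxymethyl in place of cyclopropyl on a saturated chain carbon bound to an oxygen on an aromatic ring. The measured steps give no readable size, so no direction beyond the scatter can be expected; every neighbour of compound 4 reached the limit. The step of an at least 1.1-fold lower number from compound 3 to compound 4 (0.04 log units; that floor lies within the scatter) is estimated to stay within the scatter. In this assay compound 4 is expected to give about 50000000 nM, within a range from 20000000 nM to 120000000 nM, most likely again as a limit.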

Compound 4, solubility: 43000000 nM
Estimate against measurement, compound 4: 1.2-fold (0.07 log units) above, and the stated range covers the measured number.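

In this assay compound 4 gives the first numbered value in this set, with methoxymethyl on a saturated chain carbon bound to an oxygen on an aromatic ring, whereas cyclopropyl at that place in compound 3 gave only a limit: the limit of > 55000000 nM in this assay, at which 1 of the 4 values shown sits.

The new comparisons read as an at least 1.2-fold lower number from compound 3 to compound 4 (0.10 log units; that floor lies within the scatter), an at least 1.1-fold lower number from compound 2 to compound 4 (0.06 log units; that floor lies within the scatter) and an at least 1.1-fold lower number from compound 1 to compound 4 (0.05 log units; that floor lies within the scatter). Each is only a floor within the usual scatter, so no real change with the 2-methoxyethoxy group can be claimed, and the steps among compound 1, compound 2 and compound 3 cannot be read.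

As far as these compounds go, the true distance of compound 1, compound 2 and compound 3 from compound 4 remains open. Also open, from the compounds shown here alone, is whether a terminal amine, a carboxylic acid or a longer chain at this place would give a number clearly apart from compound 4.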